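A few compounds are considered here, and "the series" means these few. Any claim that something is new, unique, unknown or untested is made for them only; others in the source may bear on it.

In a functional assay on HL-60 cells (Homo sapiens) for antiproliferative activity, with a stated time of 24 h (on this read-out higher numbers stand for weaker inhibition and lower numbers for stronger inhibition), compound 1 (`N#Cc1ccccc1CN1CCc2c(sc(NC(=O)c3ccccc3Cl)c2C(N)=O)C1`) gives 10400 nM, compound 2 (`NC(=O)c1c(NC(=O)c2ccccc2Cl)sc2c1CCN(Cc1ccc(Cl)cc1)C2`) gives 22500 nM, and compound 3 (`NC(=O)c1c(NC(=O)c2ccccc2Cl)sc2c1CCN(Cc1ccc([N+](=O)[O-])cc1)C2`) gives 11400 nM. Compound 3 stands within the scatter of both other compounds. There is a 1.1-fold higher number from compound 1 to compound 3 (0.04 log units; within the scatter), and there is a 2.0-fold lower number from compound 2 to compound 3 (0.30 log units; within the scatter). Within the data shown here, the only step that passes beyond the scatter is a 2.2-fold higher number from compound 1 to compound 2 (0.34 log units; beyond the scatter), and it is modest.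

Compound 4 (`NC(=O)c1c(NC(=O)c2ccccc2Cl)sc2c1CCN(Cc1cc(Cl)cc(Cl)c1)C2`) has not yet been measured. Its difference from compound 3 is 3,5-dichlorophenyl in place of 4-nitrophenyl on a saturated chain carbon bound to an amine nitrogen in a ring. Among the measured compounds shown here, no measured step makes this exact exchange. The nearest guide is the step that puts nitro in place of chloro on an aromatic carbon, which is a 2.0-fold lower number from compound 2 to compound 3 (0.30 log units; within the scatter). Read in reverse, it points towards a higher number for a chlorinated compound, and compound 2 carries chloro at 22500 nM. All three measured steps are small, so in this assay only a small move towards a higher number is expected, probably not clearly beyond the scatter. The estimated step is a 1.4-fold higher number from compound 3 to compound 4 (0.15 log units; within the scatter). For compound 4 the estimated value is 16000 nM, with an expected range from 7000 nM to 35000 nM.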

Compound 4, half-maximal inhibitory concentration: 15800 nM
Estimate against measurement, compound 4: 1.0-fold (0.01 log units) above, within the range that was stated.
By their numbers in this assay, from the lowest: compounds 1, 3, 4 and 2 (each within the scatter of the next, the first and the last beyond it).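

In this assay, 3,5-dichlorophenyl on a saturated chain carbon bound to an amine nitrogen in a ring stays within the scatter of all three groups seen earlier at this place: the readings are a 1.4-fold higher number from compound 3 to compound 4 (0.14 log units; within the scatter), a 1.4-fold lower number from compound 2 to compound 4 (0.15 log units; within the scatter) and a 1.5-fold higher number from compound 1 to compound 4 (0.18 log units; within the scatter). Among these compounds, this is the first group here with two chlorines on the phenyl ring, and the first exchange that replaces 4-nitrophenyl, with its hydrogen-bond acceptors, by a group that has none, yet neither difference produces a step beyond the scatter. Nothing shown gives a reason why these exchanges change the number so little.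

On these data alone, all four compounds carry a substituted phenyl ring on a single saturated carbon, so it remains open how a dimethylamino group or a carboxylic acid on that ring, a pyridine ring in its place, or a longer chain leading to it would read in this assay. The shared core is the same throughout, so these compounds also leave open whether a change elsewhere, such as replacing the chloro on the benzamide ring with methoxy, would move the number further than any exchange at this place has.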